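Phenyl Replaces Propyl: An Expected Shift in Antagonist Potency

A few compounds are considered here, and "the series" means these few. Any claim that something is new, unique, unknown or untested is made for them only; others in the source may bear on it.

Compound 1 `CC1(C)CC(=O)c2cc(C#N)c(N3CCc4ccccc4C3)nc2C1` gives 1500 nM in an in vitro functional assay on cells for antagonist activity at metabotropic glutamate receptor 1 (Rattus norvegicus), read by inositol phosphate accumulation; on this read-out higher numbers stand for weaker inhibition and lower numbers for stronger inhibition. Compound 2 `CCCCNc1nc2c(cc1C#N)C(=O)CC(C)(C)C2` gives 1700 nM. Compound 3 `CC1(C)CC(=O)c2ccc(OCc3ccccc3)nc2C1` gives 21000 nM.

Compound 2 holds the second highest of the three numbers in this assay: its value lies within the scatter of compound 1, while compound 3 sits far beyond the scatter above both. Compound 4 `CC1(C)CC(=O)c2cc(C#N)c(NCc3ccccc3)nc2C1` differs from compound 2 in one place: phenyl in place of propyl on a saturated chain carbon bound to a nitrogen on an aromatic ring. For the measured compounds named here, no measured pair shows this change directly, so the expected step of a 1.7-fold lower number from compound 2 to compound 4 (0.23 log units; within the scatter) rests on the closeness of compound 1 and compound 2, suggesting a small shift toward stronger inhibition, possibly none beyond the scatter. Compound 4 is therefore estimated at 1000 nM, with a likely range from 300 nM to 4000 nM.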

Compound 4, half-maximal inhibitory concentration: 2500 nM
The estimate for compound 4 lay 2.5-fold (0.40 log units) below the measured number; the measured number falls inside the stated range.
By their numbers in this assay, from the lowest: compounds 1, 2 and 4 (each within the scatter of the next); then compound 3.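

For the compounds shown here, the step of a 1.5-fold higher number from compound 2 to compound 4 (0.17 log units; within the scatter) in this assay gives the first direct reading at this position: phenyl in place of propyl, or butyl to benzyl when cut one bond further out, does not move the number beyond the scatter. An aromatic ring on this chain is therefore compatible with a value in the range of the butyl compound. No measurement given here accounts for this step. The compounds shown leave open whether a longer chain or an amine at the end of this chain would take the number beyond the scatter.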